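Dimethylsulfamoyl in place of butoxycarbonyl on the ring amine

The source may report more compounds than this note shows. Statements on the series, on what has been measured and on what is new or still open speak of the compounds shown alone.

Measured so far, largest response in a functional assay on CHO-K1 cells with Glucose-dependent insulinotropic receptor (Homo sapiens) as the target, read by a luciferase reporter, with a stated time of 5 h; on this read-out higher numbers stand for larger maximal responses and lower numbers for smaller maximal responses:
compound 1 `CC(C)OC(=O)N1CCC(Oc2ncnc3c2CCN3c2ccc(S(C)(=O)=O)cc2)CC1` gives 154%
compound 2 `CC(C)OC(=O)N1CCC(Oc2ncnc3c2CCN3c2ccc(C#N)cc2F)CC1` gives 134%
compound 3 `CCCCOC(=O)N1CCC(Oc2ncnc3c2CCN3c2ccc(S(C)(=O)=O)cc2F)CC1` gives 131%

Compound 3 has the lowest of the three numbers. Its nearest neighbour is compound 2, whose number is higher by an amount within the scatter, so the two cannot be ordered. Compound 1 is furthest, its number higher by an amount beyond the scatter.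

Compound 4 `CN(C)S(=O)(=O)N1CCC(Oc2ncnc3c2CCN3c2ccc(S(C)(=O)=O)cc2F)CC1` is not yet measured. Its change from compound 3 is dimethylsulfamoyl in place of butoxycarbonyl on an amine nitrogen in a ring.

Within the data shown here, the one measured step, a number 20 percentage points lower from compound 1 to compound 2 (beyond the scatter), concerns the aryl group on the ring nitrogen of the shared core and leaves the carbamate on the ring amine untouched. Among the measured compounds shown here, nothing measured in this set touches the group on the amine nitrogen in a ring, so no measured step bears on the change to compound 4, and its size and direction cannot be read from the data.

For the measured compounds named here, with no comparable step, compound 4 is expected to stay near compound 3, the estimated step being a number 6 percentage points lower from compound 3 to compound 4 (within the scatter), with a wide range. For compound 4 in this assay the estimate is 125%, between 85% and 165%.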

Compound 4, largest response reached (reported as percent of maximum), in percent of the reference or control that the assay uses: 68%
For compound 4 the middle estimate is 57 percentage points above the measured one; measured number outside the range, below it.
By their numbers in this assay, from the lowest: compound 4; then compounds 3 and 2 (each within the scatter of the next); then compound 1.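

In this assay, the group on the amine nitrogen in a ring proves a sensitive position: dimethylsulfamoyl in place of butoxycarbonyl gives a number 63 percentage points lower from compound 3 to compound 4 (beyond the scatter), a large step, where the change of aryl group on the shared core gave the modest a number 20 percentage points lower from compound 1 to compound 2 (beyond the scatter). Among these compounds, the two groups have the same counts of hydrogen-bond donors and acceptors and neither carries a net charge, so those counts do not separate them, and compound 4 alone carries this drop, being the only compound here without a carbamate on this nitrogen. Nothing available here accounts for the size of the drop.

Open, as far as these compounds go, is whether the fall follows the loss of the carbamate or the arrival of the sulfamoyl group, a question that a dimethylcarbamoyl or an ethylsulfonyl group on the same nitrogen of compound 3 would help to settle. The isopropoxycarbonyl and butoxycarbonyl groups occur here only with different aryl groups, so the effect of the carbamate chain on this read-out cannot be read.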